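Regioisomeric chlorothiophene swap on a pyridinone-ether MCH receptor series

The source may hold more compounds than are shown below. What is called first, only, known or untested is meant among the compounds shown, and "the series" means these compounds.

Measured compounds:
compound 1 `Cn1c(C2CC2)nc2ccc(-n3ccc(OCc4ccc(F)cc4)cc3=O)cc21` 40 nM
compound 2 `Cn1c(C2CC2)nc2ccc(-n3ccc(OCc4ccccc4Cl)cc3=O)cc21` 160 nM
compound 3 `Cn1c(C2CC2)nc2ccc(-n3ccc(OCc4ccc(Cl)s4)cc3=O)cc21` 19 nM

In an assay on CHO cells for displacement of a labelled ligand from melanin-concentrating hormone receptor 1 (Homo sapiens), read by scintillation counting, with a stated time of 1 h (on this read-out lower numbers stand for stronger inhibition and higher numbers for weaker inhibition), compound 3 gives the lowest number of the three. Its nearest neighbour is compound 1, a 2.1-fold lower number from compound 1 to compound 3 (0.32 log units; beyond the scatter); the furthest is compound 2, an 8.4-fold lower number from compound 2 to compound 3 (0.93 log units; beyond the scatter). Compound 4 `Cn1c(C2CC2)nc2ccc(-n3ccc(OCc4csc(Cl)c4)cc3=O)cc21` is not yet measured. It differs from compound 3 only in the attachment of the same ring: 5-chlorothiophen-3-yl in place of 5-chlorothiophen-2-yl on a saturated chain carbon bound to an oxygen on an aromatic ring. No measured step bears directly on this change; the steps shown swap whole aryl groups, a 4.0-fold higher number from compound 1 to compound 2 (0.60 log units; beyond the scatter) and a 2.1-fold lower number from compound 1 to compound 3 (0.32 log units; beyond the scatter), and each was modest. Moving within one ring is expected to matter less than exchanging rings, so a small step toward a higher number is expected, a 2.4-fold higher number from compound 3 to compound 4 (0.37 log units; beyond the scatter). Compound 4 is therefore estimated at 45 nM, within 15 nM to 140 nM in this assay.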

Compound 4, half-maximal inhibitory concentration: 14 nM
Compound 4: the middle estimate sits 3.2-fold (0.51 log units) above what was measured, and the stated range ends above it.
By their numbers in this assay, from the lowest: compounds 4 and 3 (each within the scatter of the next); then compound 1; then compound 2.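

Whether the chlorothiophene ring is attached as 5-chlorothiophen-2-yl or as 5-chlorothiophen-3-yl on the saturated chain carbon makes no difference that can be read in this assay (a 1.4-fold lower number from compound 3 to compound 4 (0.13 log units; within the scatter)). Among these compounds, the 5-chlorothiophen-3-yl group also stands clear of both phenyl groups (a 2.9-fold lower number from compound 1 to compound 4 (0.46 log units; beyond the scatter); an 11-fold lower number from compound 2 to compound 4 (1.06 log units; beyond the scatter)), and the second of these is the first large step at this position. Nothing shown explains why the two attachments read alike.

As far as these compounds go, what a bromine or a methyl in place of the chlorine on the thiophene would do remains open. So does the effect of a pyridine ring at this position.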